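Microsomal stability notes: methyl addition, compound 3 to compound 4

The compounds below may be only part of what the source reports. "The series", "measured", "known", "first", "only" and "open" are said of these compounds alone.

Measured so far in an ADME assay on microsomes from liver (Homo sapiens), read by LC-MS, using NADPH, with a stated time of 30 min, tested at 1 uM; a higher number here means that more of the compound is left, a lower number that less of the compound is left:
- compound 1 `Cc1cccc2cc([C@H](C)Nc3ncnc4[nH]cnc34)c(-c3ccccc3)c(=O)n12`: 70%
- compound 2 `Cc1ccc2cc([C@H](C)Nc3ncnc(N)c3C#N)c(-c3ccccc3)c(=O)n2c1`: "not determined" (no result reported)
- compound 3 `C[C@H](Nc1nc(N)ncc1C#N)c1cc2ccc(F)cn2c(=O)c1-c1ccccc1`: 90%

Compound 3 stands highest of the two numbers in this assay; compound 1 sits lower by a gap beyond the scatter, and compound 2 contributes no number.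

Compound 4 `Cc1nc(N)nc(N[C@@H](C)c2cc3ccc(F)cn3c(=O)c2-c2ccccc2)c1C#N` is not yet measured. It differs from compound 3 by methyl in place of hydrogen on an aromatic carbon, next to the ring nitrogen and ortho to the cyano group.

Among the compounds with values here, no measured pair carries this change, so there is no step to lean on. A small shift at most is expected, and none beyond the scatter, with compound 3 already near the top of the scale. The estimate for compound 4 in this assay is 85%, in the range 65% to 98%, meaning an expected step of a number 5 percentage points lower from compound 3 to compound 4 (within the scatter).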

Compound 4, percent of the compound remaining: 83%
The estimate for compound 4 lay 2 percentage points above the measured number; measured number inside the range.
By their numbers in this assay, from the lowest: compound 1; then compounds 4 and 3 (each within the scatter of the next).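

In this assay, within the data shown here, methyl in place of hydrogen on an aromatic carbon ortho to a cyano group gives a number 7 percentage points lower from compound 3 to compound 4 (within the scatter), the first single-place comparison. This carbon therefore accepts a methyl with no shift that can be told from the scatter. Nothing available explains this result.

Still open, as far as these compounds go, is whether an ethyl chain, an amine or a carboxylic acid on this carbon would also stay within the scatter of compound 3. A single methyl pair also cannot show whether the result carries over to other cores.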